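The source may report more compounds than this note shows. Statements on the series, on what has been measured and on what is new or still open speak of the compounds shown alone.

Compound 1 `O=C(/C(=C\c1ccc(Br)cc1)S(=O)(=O)c1ccc(Br)cc1)c1ccc(Br)cc1` is the simplest member of this small set. In a functional assay on DU-145 cells (Homo sapiens) for inhibition, read by trypan blue exclusion, with a stated time of 96 h (on this read-out lower numbers stand for stronger inhibition of growth and higher numbers for weaker inhibition of growth), compound 1 gives 10000 nM. Compound 2 `O=C(/C(=C\c1ccc(F)cc1F)S(=O)(=O)c1ccc(Br)cc1)c1ccc(Br)cc1` differs from compound 1 in one place, (2,4-difluorophenyl in place of 4-bromophenyl on a double-bonded chain carbon bound to a double-bonded chain carbon), and in this assay compound 2 gives 7500 nM, so that a 1.3-fold lower number from compound 1 to compound 2 (0.12 log units; within the scatter). Compound 3 `Cc1ccc(S(=O)(=O)/C(=C/c2ccc(Br)cc2)C(=O)c2ccc(Br)cc2)cc1` stands on a different core; how the core of compound 3 differs from the core of compound 1 is methyl in place of bromo on an aromatic carbon. In this assay compound 3 gives 10000 nM, and no change at the digits printed from compound 1 to compound 3 (within the scatter), leaving the two level at the digits reported.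

Compound 4 `Cc1ccc(S(=O)(=O)/C(=C/c2ccc(F)cc2F)C(=O)c2ccc(Br)cc2)cc1` has not yet been measured in this assay. Among the compounds with values here, it differs from compound 3 by 2,4-difluorophenyl in place of 4-bromophenyl on a double-bonded chain carbon bound to a double-bonded chain carbon, which is the same change, at the same place, as the one that separates compound 2 from compound 1, where it gave a 1.3-fold lower number from compound 1 to compound 2 (0.12 log units; within the scatter). For compound 4 the expected step is a 1.3-fold lower number from compound 3 to compound 4 (0.12 log units; within the scatter). That expectation rests on a 1.3-fold lower number from compound 1 to compound 2 (0.12 log units; within the scatter), a step within the scatter. Compound 4 is accordingly estimated at 7500 nM, with the number expected to fall between 4000 nM and 15000 nM.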

Compound 4, concentration for 50% growth inhibition: > 100000 nM
Compound 4 ended at the assay's limit (the forecaster's own chance of this, stated with the estimate: 20%); middle value at least 13-fold (1.12 log units) away from the limit.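

In this assay compound 4 gives > 100000 nM, which is a limit of the assay and not a number. The change from 4-bromophenyl to 2,4-difluorophenyl did not carry over from the core of compound 1 to the core of compound 3, since it now gave an at least 10-fold higher number from compound 3 to compound 4 (1.00 log units; beyond the scatter), and the two steps differ: the same change on two cores in this assay, a 1.3-fold lower number (0.12 log units; within the scatter) from compound 1 to compound 2 and an at least 10-fold higher number (1.00 log units; beyond the scatter) from compound 3 to compound 4, at least 13-fold (1.12 log units) apart, beyond the scatter of two such steps. Read the other way round, methyl in place of bromo gave an at least 13-fold higher number from compound 2 to compound 4 (1.12 log units; beyond the scatter), so the two changes do not add independently here, although this rests on a single pair of cores, shows only a minimum size for the gap, and does not show why the change behaves differently: the same change on two cores in this assay, no change at the digits printed (within the scatter) from compound 1 to compound 3 and an at least 13-fold higher number (1.12 log units; beyond the scatter) from compound 2 to compound 4, at least 13-fold (1.12 log units) apart, beyond the scatter of two such steps.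

The compounds shown leave open whether a 4-fluorophenyl or 2-fluorophenyl group would behave like 2,4-difluorophenyl on the methyl-bearing core. They also leave open whether a methoxy group, an amine or a carboxylic acid in place of that methyl would give the same result.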